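A few compounds are considered here, and "the series" means these few. Any claim that something is new, unique, unknown or untested is made for them only; others in the source may bear on it.

Measured so far:
Compound 1 `CCCc1nnc(SCC(=O)c2ccc(C)cc2)n1N1C(=O)c2ccccc2C1=O` gives > 200000 nM in a functional assay on PC-3M cells (Homo sapiens) for cytotoxicity, read by MTT assay, with a stated time of 48 h (on this read-out lower numbers stand for stronger inhibition and higher numbers for weaker inhibition), which is a limit and not a number.
Compound 2 `CCCc1nnc(SC)n1N1C(=O)c2ccccc2C1=O` gives > 200000 nM in this assay, again a limit and not a number.
Compound 3 `COc1cc(-c2nnc(SCC(=O)c3ccc(C)cc3)n2N2C(=O)c3ccccc3C2=O)cc(OC)c1OC` gives 11700 nM in this assay.

The change from compound 1 to compound 2 is hydrogen in place of (4-methylphenyl)carbonyl on a saturated chain carbon bound to a sulfur; its step is a step that the two limits leave unreadable from compound 1 to compound 2 because both values sit at the limit of > 200000 nM in this assay, at which 2 of the 3 values shown sit. The two cores differ by 3,4,5-trimethoxyphenyl in place of propyl on an aromatic carbon, with a step of an at least 17-fold lower number from compound 1 to compound 3 (1.23 log units; beyond the scatter).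

Compound 4 `COc1cc(-c2nnc(SC)n2N2C(=O)c3ccccc3C2=O)cc(OC)c1OC` is not yet measured. It differs from compound 3 by hydrogen in place of (4-methylphenyl)carbonyl on a saturated chain carbon bound to a sulfur, at a place described in the same words as for the first pair, so this is the same change. Its size in the measured pair is not readable. Compound 4 is expected to sit weaker than compound 3 by about a 6.8-fold higher number from compound 3 to compound 4 (0.83 log units; beyond the scatter), resting on compound 2 being held at the limit of > 200000 nM in this assay, at which 2 of the 3 values shown sit. In this assay compound 4 is expected to give roughly 80000 nM, between 15000 nM and 400000 nM, with a real chance of a limit only.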

Compound 4, half-maximal inhibitory concentration: > 200000 nM
Compound 4 ended at the assay's limit; the forecaster's own chance of this, stated with the estimate: 45%; middle value at least 2.5-fold (0.39 log units) away from the limit.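

In this assay, hydrogen in place of (4-methylphenyl)carbonyl on a saturated chain carbon bound to a sulfur gives an at least 17-fold higher number from compound 3 to compound 4 (1.23 log units; beyond the scatter). On these data alone, compound 4 gives > 200000 nM, a limit and not a number, so the full size of this step stays unknown. The same change on the core of compound 1 cannot be read, because both of its values are limits, so the data do not show whether the size of the step carries from one core to the other: the limit of > 200000 nM in this assay, at which 3 of the 4 values shown sit.

As far as these compounds go, it remains open whether an amine or a carboxylic acid in place of (4-methylphenyl)carbonyl would keep a measurable number in this assay. Also open, from the compounds shown here alone, is whether a phenyl group without the methyl would do so.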